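This account rests on a few compounds, and the source may have more. Where it says the series, first, only, none or still open, it means among the compounds named here.

Measured so far, in a functional assay on A2780 cells (Homo sapiens) for inhibition, read by sulforhodamine B assay, with a stated time of 72 h; a lower number here means a stronger inhibitor, a higher number a weaker inhibitor:
- compound 1 `O=C(NCc1ccc(S(=O)(=O)c2ccccc2C(F)(F)F)cc1)c1cc2cnccc2[nH]1` gives 25 nM
- compound 2 `O=C(NCc1ccc(S(=O)(=O)c2cc(F)cc(F)c2)cc1)c1cnc2nccn2c1` gives 3 nM
- compound 3 `O=C(NCc1ccc(S(=O)(=O)c2cccc(C(F)(F)F)c2)cc1)c1cc2ccncc2s1` gives 1 nM

Compound 1 has the highest number of the three in this assay, making it the weakest inhibitor so far. Compound 2 and compound 3 both lie lower, beyond the scatter. Both differ from compound 1 in the core and in the aryl group on the sulfonyl sulfur, so their values cannot be assigned to either change.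

Next in the series is compound 4 `Cc1cccc(S(=O)(=O)c2ccc(CNC(=O)c3cc4cnccc4[nH]3)cc2)c1`, which keeps the core of compound 1. The change is 3-methylphenyl in place of 2-(trifluoromethyl)phenyl on a sulfonyl sulfur. Within the data shown here, no measured pair differs in one place only, so the size of this step has no direct precedent. Among the measured compounds shown here, the only guide is that compound 3 at 1 nM and compound 2 at 3 nM, which also lack the 2-(trifluoromethyl)phenyl group, both sit well under compound 1 at 25 nM. A move to a lower number is therefore expected, though probably only part of the way to those two values, since the core of compound 1 remains. The estimated change is a 3.1-fold lower number from compound 1 to compound 4 (0.49 log units; beyond the scatter). For compound 4 the expected value is 8 nM, with an estimated range of 2 nM to 30 nM.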

Compound 4, half-maximal inhibitory concentration: 4 nM
Estimate against measurement, compound 4: 2.0-fold (0.30 log units) above; low and high end bracket the measured number.
By their numbers in this assay, from the lowest: compound 3; then compounds 2 and 4 (each within the scatter of the next); then compound 1.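

Among these compounds, with the core of compound 1 held fixed, the aryl group on the sulfonyl sulfur now proves to matter on its own in this assay: 3-methylphenyl in place of 2-(trifluoromethyl)phenyl gives a 6.3-fold lower number from compound 1 to compound 4 (0.80 log units; beyond the scatter), the first single-place step. The earlier compounds shown here could not show this, since compound 2 and compound 3 each differ from compound 1 in the core as well as in the aryl group, so the core and aryl contributions stayed mixed. No measurement of any property of these two groups is available to account for the size of the step.

The step changes the substituent and its place on the phenyl ring at once, and these two changes remain unseparated. Also open, on these data alone, are how this position on the core of compound 1 responds to other groups on the phenyl ring, such as methoxy, a chlorine atom or an amine, and whether the same aryl change has a similar effect on the cores of compound 2 and compound 3.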